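A Larger Group in Place of Hydroxy

A few compounds are considered here, and "the series" means these few. Any claim that something is new, unique, unknown or untested is made for them only; others in the source may bear on it.

Three compounds share one core and differ only in the group on the aromatic ring. Compound 1 `O=C(CSC(=S)N[C@H]1CCOC1=O)Nc1ccc(Br)cc1` and compound 2 `O=C(CSC(=S)N[C@H]1CCOC1=O)Nc1ccc(F)cc1` are measured in a functional assay on EC9706 cells (Homo sapiens) for cytotoxicity, read by MTT assay, with a stated time of 72 h (on this read-out lower numbers stand for stronger inhibition and higher numbers for weaker inhibition), where compound 1 gives 67400 nM and compound 2 gives 67100 nM. Compound 3 `O=C(CSC(=S)N[C@H]1CCOC1=O)Nc1ccc(O)cc1` reaches only the limit of the assay, > 128000 nM, so for compound 3 no number is known, only that limit (the limit of > 128000 nM in this assay, at which 1 of the 3 values shown sits). The step of an at least 1.8-fold higher number from compound 1 to compound 3 (0.27 log units; that floor lies within the scatter) and the step of an at least 1.9-fold higher number from compound 2 to compound 3 (0.28 log units; that floor lies within the scatter) both have floors that sit within the scatter, and the step of a 1.0-fold lower number from compound 1 to compound 2 (0.00 log units; within the scatter) is flat.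

Compound 4 `O=C(CSC(=S)N[C@H]1CCOC1=O)Nc1ccc(C(=O)/C=C/c2ccccc2)cc1` is not yet measured. The change is (2-phenylethenyl)carbonyl in place of hydroxy on an aromatic carbon. Going by the values given here, none of the measured steps involves a group of this kind, so they bear only loosely on it: all that is known is that going to hydroxy gave a higher number. Reversing away from hydroxy, compound 4 is expected to give a lower number, a step of an at least 4.2-fold lower number from compound 3 to compound 4 (0.63 log units; beyond the scatter), with 30000 nM estimated, between 5000 nM and 128000 nM.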

Compound 4, half-maximal inhibitory concentration: 44900 nM
Estimate against measurement, compound 4: 1.5-fold (0.18 log units) below; low and high end bracket the measured number.
By their numbers in this assay, from the lowest: compounds 4, 2 and 1 (each within the scatter of the next). At a limit, above all of these: compound 3.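

At this place on the aromatic ring, the much larger (2-phenylethenyl)carbonyl, with its own six-membered aromatic ring, gives a number that cannot be told apart from those of the two halogen compounds in this assay: the steps are a 1.5-fold lower number from compound 2 to compound 4 (0.17 log units; within the scatter) and a 1.5-fold lower number from compound 1 to compound 4 (0.18 log units; within the scatter). So bulk at this position does not by itself cost activity in these cells, and hydroxy remains the only group shown that stands apart, with an at least 2.8-fold lower number from compound 3 to compound 4 (0.45 log units; beyond the scatter) as the step from it. That step is only a floor, as compound 3 has no number, only a limit of the assay: the limit of > 128000 nM in this assay, at which 1 of the 4 values shown sits.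

As far as these compounds go, how an acetyl group, an amine or a carboxylic acid would read at this place stays open. So does whether the double bond or the second aromatic ring of the entering group counts for anything.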